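A few compounds are considered here, and "the series" means these few. Any claim that something is new, unique, unknown or untested is made for them only; others in the source may bear on it.

In a functional assay on KETR3 cells (Homo sapiens) for inhibition, read by MTT assay, with a stated time of 120 h (a higher number here means a weaker inhibitor, a lower number a stronger inhibitor), compound 1 (`CNC(=O)/C=C/c1ccc(NC(=O)Nc2ccc(Cl)c(C(F)(F)F)c2)cc1`) gives 21200 nM. Compound 2 (`O=C(CCc1ccc(NC(=O)Nc2ccc(Cl)c(C(F)(F)F)c2)cc1)NC1CCC1`) shares its core and is recorded only as a limit, > 50000 nM. Compound 2 therefore has no exact position on this scale.

Compound 3 (`CNC(=O)CCc1ccc(NC(=O)Nc2ccc(Cl)c(C(F)(F)F)c2)cc1`) follows from compound 2 by methyl in place of cyclobutyl on an amide-type nitrogen, with methyl in place of cyclobutyl on an amide-type nitrogen. This brings back the methylcarbamoyl of compound 1 while keeping the ethyl of compound 2.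

For the measured compounds named here, the one measured step that bears on this change is an at least 2.3-fold higher number from compound 1 to compound 2 (0.37 log units; beyond the scatter), which lies beyond the scatter. That step alters the cyclobutyl and the ethenyl together, and the two measurements cannot separate their shares. The change to compound 3 reverses only the first part of the step, so a modest move towards a lower number in this assay is expected, not a full return to the value of compound 1. The expected size of the move is an at least 1.6-fold lower number from compound 2 to compound 3 (0.22 log units; that floor lies within the scatter). For compound 3 the estimated value is 30000 nM, with an expected range from 12000 nM to 50000 nM.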

Compound 3, half-maximal inhibitory concentration: 24000 nM
The estimate for compound 3 lay 1.3-fold (0.10 log units) above the measured number, and the stated range covers the measured number.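

In this assay, with the rest of the structure held fixed, methyl in place of cyclobutyl on the amide-type nitrogen gives an at least 2.0-fold lower number from compound 2 to compound 3 (0.31 log units; beyond the scatter), so one part of the earlier combined step now has its own reading. The other part can be read as well: 2-(methylcarbamoyl)ethyl in place of 2-(methylcarbamoyl)ethenyl on the aromatic carbon gives a 1.1-fold higher number from compound 1 to compound 3 (0.05 log units; within the scatter), which leaves compound 1 and compound 3 indistinguishable, and among these three compounds only the one carrying cyclobutyl stands apart. Compound 2 is recorded only as a limit, so the step from it gives a floor and not a full size: the limit of > 50000 nM in this assay, at which 1 of the 3 values shown sits.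

From the compounds shown here alone, how an ethyl or an isopropyl on the amide-type nitrogen would read remains open, as does the plain primary amide, so these compounds do not show how the number in this assay follows the size of that group. Going by these compounds, it is equally open what a carboxylic acid or a longer chain in place of the 2-(methylcarbamoyl)ethyl would do on the shared core.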